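The source may report more compounds than this note shows. Statements on the series, on what has been measured and on what is new or still open speak of the compounds shown alone.

Measured so far:
- compound 1 `CCSCCn1c(=O)c2[nH]c(Cc3cccs3)nc2n(Cc2ccco2)c1=O`: 275 nM
- compound 2 `CCCn1c(=O)c2[nH]c(Cc3ccccc3)nc2n(Cc2ccco2)c1=O`: 117 nM

In an assay on HEK293 cells for displacement of a labelled ligand from adenosine receptor A2b (Homo sapiens) (on this read-out lower numbers stand for stronger inhibition and higher numbers for weaker inhibition), compound 1 gives 275 nM, the higher of the two numbers; compound 2 gives 117 nM, a gap that lies beyond the usual scatter. Compound 3 `C=CCn1c(=O)c2[nH]c(Cc3cccs3)nc2n(Cc2ccco2)c1=O` has not been measured in this assay. It differs from compound 1 by vinyl in place of (ethylsulfanyl)methyl on a saturated chain carbon bound to an aromatic nitrogen. Going by the values given here, no measured pair shows this change on its own, so the account leans on compound 2, whose shorter chain goes with the lower number of 117 nM. A modest step toward a lower number is expected, as a 1.7-fold lower number from compound 1 to compound 3 (0.24 log units; within the scatter), possibly no more than the scatter. Compound 3 is estimated at 160 nM, from 60 nM to 420 nM.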

Compound 3, inhibition constant: 550 nM
The estimate for compound 3 lay 3.4-fold (0.54 log units) below the measured number; the measured number lies above the stated range.
By their numbers in this assay, from the lowest: compound 2; then compounds 1 and 3 (each within the scatter of the next).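

Vinyl in place of (ethylsulfanyl)methyl on a saturated chain carbon bound to an aromatic nitrogen gives a 2.0-fold higher number from compound 1 to compound 3 (0.30 log units; within the scatter) in this assay and is the first step read at this position. The 2-(ethylsulfanyl)ethyl and allyl chains therefore cannot be told apart here, even though the sulfur and two heavy atoms leave with the change. Nothing measured bears on why this is so. Going by these compounds, whether an amine, a carboxylic acid or a longer chain at this position would move the number beyond the scatter remains open.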